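The compounds below may be only part of what the source reports. "The series", "measured", "known", "first", "only" and "open" are said of these compounds alone.

Compound 1 `CCCCCCCCCC(=O)O[C@H]1[C@H](O)[C@H](n2ccc(N)nc2=O)O[C@@H]1CO`: 0.09 ug/mL
Compound 2 `CCCCCCCCCC(=O)OC[C@H]1O[C@@H](n2ccc(N)nc2=O)[C@@H](O)[C@@H]1OC(=O)CCCCCCCCC`: 0.11 ug/mL
Compound 3 `CCCCCCCCCC(=O)OC[C@H]1O[C@@H](n2ccc(N)nc2=O)[C@@H](O)[C@@H]1O`: 0.1 ug/mL

In a functional assay on HeLa cells (Homo sapiens) for cytotoxicity, read by cell counting, with a stated time of 48 h (on this read-out higher numbers stand for an effect only at larger amounts of compound and lower numbers for an effect already at smaller amounts), compound 1 has the lowest of the three numbers, yet its gaps to compound 3 and to compound 2 both lie within the scatter, so the three compounds cannot be told apart. Among the compounds with values here, the only steps measured here, a 1.2-fold higher number from compound 1 to compound 2 (0.09 log units; within the scatter) and a 1.1-fold lower number from compound 2 to compound 3 (0.04 log units; within the scatter), add or remove a whole ester group and change nothing beyond the scatter. Compound 4 `CCCCCCCCCCCCCCCCCCCC(=O)O[C@H]1[C@H](O)[C@H](n2ccc(N)nc2=O)O[C@@H]1CO` is made from compound 1 by a different kind of change: decyl in place of hydrogen on a saturated chain carbon, nine bonds along the chain from a carbonyl carbon. Within the data shown here, no measured step lengthens a chain in this way, so the expectation rests on the general insensitivity seen so far. For compound 4 the estimate is 0.12 ug/mL, with a range from 0.05 ug/mL to 0.4 ug/mL, which is a step of a 1.3-fold higher number from compound 1 to compound 4 (0.12 log units; within the scatter) expected to stay within the scatter.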

Compound 4, concentration for half-maximal effect: 0.1 ug/mL
Compound 4: the middle estimate sits 1.2-fold (0.08 log units) above what was measured, within the range that was stated.
By their numbers in this assay, from the lowest: compounds 1, 3, 4 and 2 (each within the scatter of the next).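

In this assay the chain of compound 1 takes on decyl, on a saturated chain carbon, nine bonds along the chain from a carbonyl carbon, with a step inside the scatter (a 1.1-fold higher number from compound 1 to compound 4 (0.05 log units; within the scatter)). The earlier steps shown here added or removed a whole ester group; this one shows that the length of the ester chain at this position can also grow this far with no measurable change. Nothing here explains this tolerance.

The compounds shown leave open whether a much shorter chain would behave the same way. They also leave open what an amine or a carboxylic acid at the far end of this chain would do.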